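Trifluoromethoxy in Place of Trifluoromethyl on a Shared Core

The source may report more compounds than this note shows. Statements on the series, on what has been measured and on what is new or still open speak of the compounds shown alone.

Compound 1 `Oc1ccccc1-c1cc(-c2ccccc2F)cc(-c2ccccc2O)n1` shows only a limit in a functional assay on DU-145 cells (Homo sapiens) for inhibition (a lower number here means a stronger inhibitor, a higher number a weaker inhibitor), namely > 50000 nM. Compound 2 `Oc1ccccc1-c1cc(-c2ccccc2C(F)(F)F)cc(-c2ccccc2O)n1` gives 4770 nM in this assay. Among the values shown this is the only true number; the other is the limit (the limit of > 50000 nM in this assay, at which 1 of the 2 values shown sits). The step of an at least 10-fold lower number from compound 1 to compound 2 (1.02 log units; beyond the scatter) is large. Compound 3 `Oc1ccccc1-c1cc(-c2ccccc2OC(F)(F)F)cc(-c2ccccc2O)n1` differs from compound 2 by trifluoromethoxy in place of trifluoromethyl on an aromatic carbon. For the measured compounds named here, the one measured step concerns a different exchange, fluoro to trifluoromethyl, and so offers no direct guide. For compound 3 a change no larger than the scatter is expected in this assay, a 1.1-fold lower number from compound 2 to compound 3 (0.03 log units; within the scatter). The estimate for compound 3 in this assay is 4500 nM, ranging from 1500 nM to 14000 nM.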

Compound 3, half-maximal inhibitory concentration: 5850 nM
Compound 3: middle estimate off by 1.3-fold (0.11 log units), on the low side; the measured number falls inside the stated range.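

Trifluoromethoxy and trifluoromethyl are interchangeable at this position in this assay: the exchange gives a 1.2-fold higher number from compound 2 to compound 3 (0.09 log units; within the scatter). The gain over fluoro is therefore not tied to trifluoromethyl alone, as the second group also gives an at least 8.5-fold lower number from compound 1 to compound 3 (0.93 log units; beyond the scatter). Compound 1 is recorded only as a limit, so the full size of this step stays unknown: the limit of > 50000 nM in this assay, at which 1 of the 3 values shown sits.

The compounds shown leave open how an amine, a carboxylic acid or a longer chain would fare at this position. They also leave open whether any group here can give a much lower number than compound 2 and compound 3.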